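Swapping an Aromatic Ring for an Octyl Chain

A few compounds are considered here, and "the series" means these few. Any claim that something is new, unique, unknown or untested is made for them only; others in the source may bear on it.

Compound 1, `CN(C)C(=O)C[C@H](CSc1ccccc1)Nc1c(C(=O)N/N=C/c2ccc(OC(F)(F)F)cc2)cnc2c(C(F)(F)F)cccc12`, and compound 2, `COc1ccc(/C=N/NC(=O)c2cnc3c(C(F)(F)F)cccc3c2N[C@@H](CSc2ccccc2)CC(=O)N(C)C)cc1O`, share one core and differ only in the group on a carbon with a double bond to nitrogen. In an ADME assay on Vero cells (Chlorocebus sabaeus) for cytotoxicity, read by MTT assay, with a stated time of 72 h (a higher number here means a weaker inhibitor, a lower number a stronger inhibitor), compound 1 gives > 62.5 ug/mL, which is a limit of the assay rather than a number. In this assay compound 2 likewise gives > 62.5 ug/mL, again a limit. The step that the two limits leave unreadable from compound 1 to compound 2 therefore cannot be sized. Compound 3, `CCCCCCCC/C=N/NC(=O)c1cnc2c(C(F)(F)F)cccc2c1N[C@@H](CSc1ccccc1)CC(=O)N(C)C`, carries the change (octyl in place of 3-hydroxy-4-methoxyphenyl on a carbon with a double bond to nitrogen). Going by the values given here, no measured step reads on that change; the only fact bearing on it is the limit of > 62.5 ug/mL in this assay, at which 2 of the 2 values shown sit. Because both shown values sit at the limit of > 62.5 ug/mL in this assay, at which 2 of the 2 values shown sit, no step beyond the scatter can be predicted for compound 3 in this assay, though a numerical reading cannot be ruled out. Compound 3 is expected at 55 ug/mL, within 20 ug/mL to 125 ug/mL. The step of an at least 1.1-fold lower number from compound 2 to compound 3 (0.05 log units; that floor lies within the scatter) is thus expected to be small.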

Compound 3, half-maximal inhibitory concentration: > 62.5 ug/mL
Compound 3 was reported as a limit (the forecaster's own chance of this, stated with the estimate: 55%); middle value at least 1.1-fold (0.05 log units) from the limit.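

No step can be read between compound 1, compound 2 and compound 3, because each result is a limit of the assay and not a number: the limit of > 62.5 ug/mL in this assay, at which 3 of the 3 values shown sit. Left open is whether the two aromatic groups and the octyl chain differ at all in this assay and, if they do, by how much.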